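A Nitro Group Ortho to Chloro and Cell Toxicity

A few compounds are considered here, and "the series" means these few. Any claim that something is new, unique, unknown or untested is made for them only; others in the source may bear on it.

Of the compounds shown here, three from this series have been tested in an ADME assay on HEK293 cells (Homo sapiens) for cytotoxicity, read by MTT assay, with a stated time of 48 h (a higher number here means a weaker inhibitor, a lower number a stronger inhibitor), and a fourth awaits its result.

Compound 1, `Cc1cc(NC(=O)c2ccc(Cl)cc2)ccc1NS(C)(=O)=O`, is the plainest of the set. In this assay compound 1 gives 50300 nM. Compound 2, `Cc1cc(NC(=O)c2ccc(Cl)c([N+](=O)[O-])c2)ccc1NS(C)(=O)=O`, differs from it in one spot: nitro in place of hydrogen on an aromatic carbon. In this assay compound 2 gives 73100 nM, and the step is a 1.5-fold higher number from compound 1 to compound 2 (0.16 log units; within the scatter), so the two values cannot be told apart by this measurement.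

Compound 3, `COc1cc(NC(=O)c2ccc(Cl)cc2)ccc1NS(=O)(=O)C(F)(F)F`, carries a different core; how it differs from the core of compound 1 is not broken down here. For compound 3 the result in this assay is a limit rather than a number, > 250000 nM. This is the limit of > 250000 nM in this assay, at which 1 of the 3 values shown sits.

Compound 4, `COc1cc(NC(=O)c2ccc(Cl)c([N+](=O)[O-])c2)ccc1NS(=O)(=O)C(F)(F)F`, is built from compound 3 by the same change that turned compound 1 into compound 2: nitro in place of hydrogen on an aromatic carbon.

What to expect for compound 4 rests on two things. The earlier step of a 1.5-fold higher number from compound 1 to compound 2 (0.16 log units; within the scatter) was small, and compound 3 already sits at > 250000 nM. The step from compound 3 to compound 4 is therefore estimated to be a step that the limit leaves unreadable from compound 3 to compound 4. Compound 4 is expected to give about 300000 nM, most likely reported again as a limit, in a range from 150000 nM to 600000 nM.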

Compound 4, half-maximal inhibitory concentration: > 250000 nM
Compound 4: only a limit was reported (the forecaster's own chance of this, stated with the estimate: 80%); the middle value is on the limit's open side.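

Compound 3 and compound 4 are each reported only as a limit in this assay, so no step can be read between them, and the effect of the nitro group on this core stays hidden: the limit of > 250000 nM in this assay, at which 2 of the 4 values shown sit.

The compounds shown leave open where the true values of compound 3 and compound 4 lie, and whether nitro in place of hydrogen changes anything on the core of compound 3.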